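The source may hold more compounds than are shown below. What is called first, only, known or untested is meant among the compounds shown, and "the series" means these compounds.

In a functional assay on K562 cells (Homo sapiens) for inhibition, read by sulforhodamine B assay, with a stated time of 48 h (a lower number here means a stronger inhibitor of growth, a higher number a weaker inhibitor of growth), compound 2 `O=C(NNC(=O)c1cc2ccccc2cc1O)c1ccc2[nH]c(-c3ccc([N+](=O)[O-])s3)nc2c1` gives 31.3 ug/mL. Compound 3 `COc1cc(C(=O)NNC(=O)c2ccc3[nH]c(-c4ccc([N+](=O)[O-])o4)nc3c2)cc(OC)c1OC` gives 31.3 ug/mL, the same number at the digits shown. Compound 1 `COc1cccc(C(=O)NNC(=O)c2ccc3[nH]c(-c4ccc([N+](=O)[O-])o4)nc3c2)c1` gives 15.6 ug/mL, and its gap to compound 2 lies within the scatter, so the three values cannot be ranked. Among the compounds with values here, no two measured compounds differ in one place only, so no measured step bears directly on the next comparison.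

Compound 4 `COc1cccc(C(=O)NNC(=O)c2ccc3[nH]c(-c4ccc([N+](=O)[O-])s4)nc3c2)c1` keeps the core of compound 2 and has 3-methoxyphenyl in place of 3-hydroxynaphthalen-2-yl on a carbonyl carbon. The closest guide is indirect. Compound 1 carries the same 3-methoxyphenyl on a carbonyl carbon, but on a different core, and gives 15.6 ug/mL. Compound 1 and compound 3 share a core and differ in the group on that carbonyl carbon, and with compound 1 at 15.6 ug/mL and compound 3 at 31.3 ug/mL, their values also sit within the scatter of each other. No change beyond the scatter is therefore expected, with only a slight lean towards a lower number. The expected change is a 1.6-fold lower number from compound 2 to compound 4 (0.19 log units; within the scatter), an estimate that stays within the scatter. For compound 4 the estimated value is 20 ug/mL, with an expected range of 8 ug/mL to 50 ug/mL.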

Compound 4, concentration for 50% growth inhibition: 15.6 ug/mL
Compound 4: middle estimate off by 1.3-fold (0.11 log units), on the high side; measured number inside the range.
By their numbers in this assay, from the lowest: compounds 1, 4, 2 and 3 (each within the scatter of the next).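

Within the data shown here, these are the first single-place comparisons, and both stay within the scatter in this assay. On a carbonyl carbon whose other neighbour is an amide-type nitrogen, 3-methoxyphenyl in place of 3-hydroxynaphthalen-2-yl gives a 2.0-fold lower number from compound 2 to compound 4 (0.30 log units; within the scatter), so exchanging the group with two six-membered aromatic rings for the group with one does not separate the two compounds in this assay, and the hydroxyl-bearing group shows no measurable advantage here. At the other site, 5-nitrothiophen-2-yl in place of 5-nitrofuran-2-yl on an aromatic carbon gives no change at the digits printed from compound 1 to compound 4 (within the scatter), so the measured data do not distinguish these two nitro-bearing rings when 3-methoxyphenyl is held constant, and no available evidence bears on why either exchange leaves the reading within the scatter.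

The compounds shown do not reveal whether any group at either site moves the number beyond the scatter, for example a carboxylic acid or a longer chain ending in an amine in place of 3-methoxyphenyl on the carbonyl carbon. Also open, from the compounds shown here alone, is what an amine in place of the nitro group on the 5-nitrothiophen-2-yl ring would do.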